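Changing the Group on a Ring Nitrogen: Compound 1 to Compound 4

The source may hold more compounds than are shown below. What is called first, only, known or untested is meant among the compounds shown, and "the series" means these compounds.

Measured so far:
compound 1 `Nc1ccccc1NC(=O)c1ccc(CSC(=S)N2CCN(c3ccc(F)cc3)CC2)cc1`, 18.8%
compound 2 `Nc1ccccc1NC(=O)c1ccc(CSC(=S)N2CCc3cc(Cl)ccc32)cc1`, 57.7%
compound 3 `CC1CCN(C(=S)SCc2ccc(C(=O)Nc3ccccc3N)cc2)CC1`, 28.1%

In a functional assay on MGC-803 cells (Homo sapiens) for antiproliferative activity, read by CCK-8 assay, with a stated time of 72 h, tested at 2 uM (a lower number here means a weaker effect, a higher number a stronger effect of the compound at the concentration tested), compound 1 gives 18.8%, which puts it at the low end of the three numbers. Compound 3 lies within the usual scatter of compound 1, while compound 2 stands beyond the scatter above both. Compound 4 `Nc1ccccc1NC(=O)c1ccc(CSC(=S)N2CCN(Cc3cccnc3)CC2)cc1` differs from compound 1 in one place: (pyridin-3-yl)methyl in place of 4-fluorophenyl on an amine nitrogen in a ring. Within the data shown here, the only measured step, a number 29.6 percentage points lower from compound 2 to compound 3 (beyond the scatter), concerns a different group on a thiocarbonyl carbon and therefore does not bear on a change at the ring nitrogen. Among the measured compounds shown here, with no measured step for this change, the expectation rests on compound 1 alone and is wide. Compound 4 is expected to give about 25%, with a range from 8% to 48%. This expected change, a number 6.2 percentage points higher from compound 1 to compound 4 (within the scatter), stays within the scatter.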

Compound 4, a percentage reported as inhibition, at one concentration (the size of the read-out at that concentration, not a potency): 37.7%
The estimate for compound 4 lay 12.7 percentage points below the measured number; the range from low to high includes it.
By their numbers in this assay, from the lowest: compounds 1, 3 and 4 (each within the scatter of the next, the first and the last beyond it); then compound 2.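

In this assay, the group on the ring nitrogen affects the result, with a number 18.9 percentage points higher from compound 1 to compound 4 (beyond the scatter). The entering and leaving groups have the same heavy-atom count, but (pyridin-3-yl)methyl adds a carbon link, a ring nitrogen and a hydrogen-bond acceptor, so this single step cannot show which feature matters. No available evidence accounts for this rise.

The compounds shown leave open whether a benzyl group, which has the carbon link without the ring nitrogen, would behave like (pyridin-3-yl)methyl. They also leave open how a pyridin-3-yl group attached directly to the ring nitrogen would compare.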